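A few compounds are considered here, and "the series" means these few. Any claim that something is new, unique, unknown or untested is made for them only; others in the source may bear on it.

Compounds measured in a functional assay on DU-145 cells (Homo sapiens) for inhibition, read by trypan blue exclusion, with a stated time of 96 h; on this read-out lower numbers stand for stronger inhibition of growth and higher numbers for weaker inhibition of growth:
- Compound 1 `COc1cc(/C=C(/Sc2ccc(Br)cc2)C(=O)c2ccc(Br)cc2)ccc1O`: 1000 nM
- Compound 2 `COc1ccc(/C=C(/Sc2ccc(Br)cc2)C(=O)c2ccc(Br)cc2)cc1`: 25000 nM
- Compound 3 `COc1ccc(/C=C(/SCc2ccc(Cl)cc2)C(=O)c2ccc(Br)cc2)cc1`: 10000 nM

Compound 2 has the highest number of the three, which makes it the weakest growth inhibitor here. Compound 3 lies nearest to it and compound 1 furthest away. The unmeasured compound 4 `COc1cc(/C=C(/Sc2ccc(Br)cc2)C(=O)c2ccc(Br)cc2)ccc1F` alters compound 2 at a single place, on a double-bonded chain carbon bound to a double-bonded chain carbon: 4-fluoro-3-methoxyphenyl in place of 4-methoxyphenyl on a double-bonded chain carbon bound to a double-bonded chain carbon.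

The most relevant evidence is a 25-fold higher number from compound 1 to compound 2 (1.40 log units; beyond the scatter), a large step at that same place, where 4-methoxyphenyl replaced 4-hydroxy-3-methoxyphenyl. The new 4-fluoro-3-methoxyphenyl group matches the group of compound 1 except for fluoro in place of hydroxy. Within the data shown here, no fluoro compound has been measured, so how much of that gap returns is a judgement, and only part of it is expected to. The modest 2.5-fold lower number from compound 2 to compound 3 (0.40 log units; beyond the scatter) was made on the sulfur, a different place, and says little here.

A moderate move to a lower number is therefore expected in this assay. The expected change is a 5.0-fold lower number from compound 2 to compound 4 (0.70 log units; beyond the scatter). Compound 4 is estimated at 5000 nM, with an expected range of 1200 nM to 20000 nM.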

Compound 4, concentration for 50% growth inhibition: 10000 nM
Estimate against measurement, compound 4: 2.0-fold (0.30 log units) below; the measured number falls inside the stated range.
By their numbers in this assay, from the lowest: compound 1; then compounds 3 and 4 (each within the scatter of the next); then compound 2.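

In this assay, the step of a 2.5-fold lower number from compound 2 to compound 4 (0.40 log units; beyond the scatter) shows that the 4-fluoro-3-methoxyphenyl group on this double-bonded chain carbon improves on 4-methoxyphenyl even without a hydroxy group, so the hydroxy group is not needed for some gain at this position. The step of a 10-fold higher number from compound 1 to compound 4 (1.00 log units; beyond the scatter) then compares fluoro with hydroxy directly on an aromatic carbon and shows that fluoro recovers only part of the difference seen in the earlier step of a 25-fold higher number from compound 1 to compound 2 (1.40 log units; beyond the scatter), leaving compound 1 clearly ahead. The data shown contain no separate measurement that explains why hydroxy and fluoro differ in this way.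

On these data alone, it remains open whether another group in that same place, such as an amine or a carboxylic acid in place of the fluoro, would come closer to compound 1 or fall back towards compound 2. Also open, as far as these compounds go, is whether the gain from the 4-fluoro-3-methoxyphenyl group would carry over to a compound with 4-chlorobenzyl on the sulfur, as in compound 3.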